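Cytotoxicity notes on the shared core series

The source may report more compounds than this note shows. Statements on the series, on what has been measured and on what is new or still open speak of the compounds shown alone.

Compound 1 `CC(C)N(Cc1cccc(OCCCCCC(=O)O)c1)C(=O)c1ccc(-c2ccsc2)cc1` carries thiophen-3-yl on the shared core. In an ADME assay on HEK293 cells (Homo sapiens) for cytotoxicity, read by CellTiter-Glo and resazurin assay, with a stated time of 72 h (on this read-out lower numbers stand for an effect already at smaller amounts and higher numbers for an effect only at larger amounts of compound), compound 1 gives only a limit, > 26000 nM. Compound 2 `CC(C)N(Cc1cccc(OCCCCCC(=O)O)c1)C(=O)c1ccc(-c2c[nH]c3ccccc23)cc1` carries 1H-indol-3-yl on the same core. In this assay compound 2 likewise gives only a limit, > 26000 nM. The step that the two limits leave unreadable from compound 1 to compound 2 is therefore not readable in size. Both readings sit at the limit of > 26000 nM in this assay, at which 2 of the 2 values shown sit. Compound 3 `COc1cc(F)cc(-c2ccc(C(=O)N(Cc3cccc(OCCCCCC(=O)O)c3)C(C)C)cc2)c1` is not yet measured; it differs from compound 2 by 3-fluoro-5-methoxyphenyl in place of 1H-indol-3-yl on an aromatic carbon. Going by the values given here, no measured step bears on this change directly, and the single measured step, from thiophen-3-yl to 1H-indol-3-yl, left the read-out at the limit on both sides, so no shift beyond the scatter is expected here either. For compound 3 the expected step that the limit leaves unreadable from compound 2 to compound 3 is accordingly none beyond the scatter. Compound 3 is expected to give 40000 nM in this assay, most likely again reported only as a limit, within 20000 nM to 100000 nM.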

Compound 3, half-maximal effective concentration: > 26000 nM
Compound 3: a limit, no number; the forecaster's own chance of this, stated with the estimate: 85%; the middle value does not contradict the limit.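

Going by these compounds alone, compound 1, compound 2 and compound 3 all give only a limit in this assay, so no step among them can be read: the limit of > 26000 nM in this assay, at which 3 of the 3 values shown sit. From the compounds shown here alone, whether any group at this place on the shared core gives a number rather than a limit remains open.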